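Swapping cyclohexyl for trifluoromethoxyphenyl: cytotoxicity expected

The source may report more compounds than this note shows. Statements on the series, on what has been measured and on what is new or still open speak of the compounds shown alone.

The account concerns three compounds whose tolerance on liver-derived cells has been measured, and one whose measurement is awaited. Compound 1 `CN1CCN(CCCNCc2cn(-c3ccc(C(F)(F)F)cc3)nc2-c2ccc(OC(F)(F)F)cc2)CC1` carries a 4-(trifluoromethoxy)phenyl group on the shared core; in an ADME assay on Huh-7 cells (Homo sapiens) for cytotoxicity (a lower number here means that less compound is tolerated, a higher number that more compound is tolerated), compound 1 gives 2300 nM. Compound 2 `CN1CCN(CCNCc2cn(-c3ccc(F)cc3F)nc2C2CCCCC2)CC1` instead bears a cyclohexyl group at the same position of the core. In this assay compound 2 reaches only the limit of the measurement, > 20000 nM, and no number is available for it. Compound 3 `Cc1ccccc1-c1nn(-c2ccc(F)cc2F)cc1CNCCN1CCCCC1` likewise returns only a limit in this assay, > 20000 nM. So compound 2 stands at the limit, in the company of compound 3, as the evidence summarises: the limit of > 20000 nM in this assay, at which 2 of the 3 values shown sit.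

Compound 4 `CN1CCN(CCNCc2cn(-c3ccc(F)cc3F)nc2-c2ccc(OC(F)(F)F)cc2)CC1` differs from compound 2 in one place: 4-(trifluoromethoxy)phenyl in place of cyclohexyl on an aromatic carbon. Compound 1, which carries the same entering group on a different arrangement of the rest of the molecule, sits at a measured number rather than a limit, so the step from compound 2 to compound 4 is expected to move towards lower tolerance, beyond the scatter, though its size is uncertain. The expected step is an at least 2.8-fold lower number from compound 2 to compound 4 (0.45 log units; beyond the scatter). For compound 4 the estimate in this assay is 7000 nM, within a range from 2500 nM to 20000 nM.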

Compound 4, half-maximal cytotoxic concentration: 18000 nM
Compound 4: middle estimate off by 2.6-fold (0.41 log units), on the low side; the measured number falls inside the stated range.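

Setting 4-(trifluoromethoxy)phenyl in place of cyclohexyl on this aromatic carbon gives, in this assay, an at least 1.1-fold lower number from compound 2 to compound 4 (0.04 log units; that floor lies within the scatter). Compound 4 gives 18000 nM, a number rather than a limit, and it is the first compound shown with a 2,4-difluorophenyl group on the shared core to do so. The true size of the change cannot be read, because compound 2 stands only at a limit of the assay: the limit of > 20000 nM in this assay, at which 2 of the 4 values shown sit.

The compounds shown leave open how this position responds to other groups, such as an unsubstituted phenyl, a 4-methoxyphenyl or a cyclohexyl ring carrying an amine, as cyclohexyl and 4-(trifluoromethoxy)phenyl are the only pair here that differ in one place. They also leave open whether the same replacement would give a comparable step on the side chain of compound 1 or of compound 3, rather than on the side chain shared by compound 2 and compound 4.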